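The compounds below may be only part of what the source reports. "The series", "measured", "known", "first", "only" and "open" are said of these compounds alone.

Working notes on the distribution series. Among the compounds with values here, in an in vivo ADME assay on the whole organism for pharmacokinetics, with Rattus norvegicus as the target, at a dose of 0.5 mg/kg by the intravenous route (on this read-out lower numbers stand for narrower distribution and higher numbers for wider distribution into tissues), compound 1 `CC(=O)Nc1cc(-c2c(Nc3cc[nH]n3)nc3cccnn23)nc(C)n1` gives 6.3 L/kg, the highest of the three numbers measured so far. Compound 2 `CC(=O)Nc1cc(-c2c(Nc3ccn(C)n3)nc3cccnn23)nc(C)n1` gives 0.8 L/kg in this assay, and compound 3 `CC(=O)Nc1cc(-c2c(Nc3ccn(C)n3)nc3ccccn23)nc(C)n1` gives 0.6 L/kg. Within the data shown here, the only single-point step measured is a 7.9-fold lower number from compound 1 to compound 2 (0.90 log units; beyond the scatter), and it lies beyond the scatter; the gap from compound 1 to compound 3 is wider still, while compound 2 and compound 3 lie within the scatter of each other.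

Compound 4 `CNc1cc(-c2c(Nc3cc[nH]n3)nc3cccnn23)nc(C)n1` is not yet measured. It differs from compound 1 in one place: methyl in place of acetyl on a nitrogen on an aromatic ring Cut one bond further out, the difference reads acetamido to methylamino; the nitrogen on the aromatic ring keeps one aromatic carbon as its other neighbour.

Among the measured compounds shown here, none of the measured steps bears on this change. For the measured compounds named here, the one step available swaps hydrogen for methyl on an aromatic nitrogen of the pyrazole, a different site, and says nothing about what the acetamido nitrogen carries. The expectation therefore rests on compound 1 alone, with its value 6.3 L/kg as anchor, and the expected step is a 1.0-fold higher number from compound 1 to compound 4 (0.01 log units; within the scatter), within the scatter. Compound 4 is estimated at 6.5 L/kg, with a range from 2.8 L/kg to 15 L/kg.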

Compound 4, volume of distribution at steady state in the Rattus norvegicus assay: 1.3 L/kg
Compound 4: the middle estimate sits 5.0-fold (0.70 log units) above what was measured; measured number below the stated range.
By their numbers in the Rattus norvegicus assay, from the lowest: compounds 3, 2 and 4 (each within the scatter of the next, the first and the last beyond it); then compound 1.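

At the nitrogen on the aromatic ring, the exchange of acetamido for methylamino is not neutral for distribution: in the Rattus norvegicus assay it gives a 4.8-fold lower number from compound 1 to compound 4 (0.69 log units; beyond the scatter). This places a second change on compound 1, at a different site from the aromatic nitrogen of the pyrazole, that gives a number beyond the scatter, so what this nitrogen carries counts for the read-out. The same pair also separates on another read-out: in a physicochemical assay for solubility, in simulated intestinal fluid (a lower number here means a less soluble compound, a higher number a more soluble compound), compound 1 gives 200 ug/mL and compound 4 gives 7 ug/mL, though a single pair cannot tell whether the two read-outs move together in general.

The compounds shown leave open how both read-outs respond to other groups on this nitrogen, such as an unsubstituted amine or a longer acyl chain like propionyl. Also open, as far as these compounds go, is whether the exchange of acetyl for methyl carries over to compound 2, which has the methyl on the pyrazole nitrogen, or to the core of compound 3.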